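Swapping a branched aryl group for a hydroxyphenyl on the shared core

This account rests on a few compounds, and the source may have more. Where it says the series, first, only, none or still open, it means among the compounds named here.

Measured so far:
compound 1 `COc1cc2c(Nc3ccccc3[N+](=O)[O-])ncnc2c(OC)c1OC` gives 21000 nM
compound 2 `COc1cc2c(N[C@@H](C)c3ccccc3)ncnc2c(OC)c1OC` gives 11900 nM

In a functional assay on BGC-823 cells (Homo sapiens) for inhibition, read by MTT assay, with a stated time of 72 h (on this read-out lower numbers stand for stronger inhibition and higher numbers for weaker inhibition), compound 2 gives the lower of the two numbers, but the gap to compound 1 lies within the usual scatter, so the two cannot be ranked. Compound 3 `COc1cc2c(Nc3ccc(O)cc3)ncnc2c(OC)c1OC` is the next step from compound 2: 4-hydroxyphenyl in place of 1-phenylethyl on a nitrogen on an aromatic ring. For the measured compounds named here, no measured pair shows a single change of this kind, so any expectation rests on the two values alone. For compound 3 the expected outcome is a step of a 1.3-fold higher number from compound 2 to compound 3 (0.10 log units; within the scatter), most likely no change beyond the scatter. Compound 3 is therefore estimated at 15000 nM, within a range from 5000 nM to 45000 nM.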

Compound 3, half-maximal inhibitory concentration: 35400 nM
The estimate for compound 3 lay 2.4-fold (0.37 log units) below the measured number; low and high end bracket the measured number.
By their numbers in this assay, from the lowest: compounds 2, 1 and 3 (each within the scatter of the next, the first and the last beyond it).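

The group on this nitrogen on an aromatic ring does matter: in this assay placing 4-hydroxyphenyl where 1-phenylethyl stood gives a 3.0-fold higher number from compound 2 to compound 3 (0.47 log units; beyond the scatter) and so a modest weakening, a difference that compounds 1 and 2 could not show. This one swap removes a defined stereocentre and adds a hydrogen-bond donor, so the step cannot be assigned to either change alone. Nothing here explains the step.

Going by these compounds, it remains open whether an amine or a methoxy group in place of the hydroxy group would give a similar number.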